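The compounds below may be only part of what the source reports. "The series", "measured", "known", "first", "only" and "open" are said of these compounds alone.

Measured in a functional assay on SW1990 cells (Homo sapiens) for cytotoxicity, read by MTT assay, with a stated time of 48 h; on this read-out higher numbers stand for weaker inhibition and lower numbers for stronger inhibition:
- compound 1 `O=C(c1ccc2cccc(O)c2n1)N1CCC(Oc2no[n+]([O-])c2S(=O)(=O)c2ccccc2)CC1`: 6590 nM
- compound 2 `O=C(NCCCOc1no[n+]([O-])c1S(=O)(=O)c1ccccc1)c1ccc2cccc(OCc3ccc(B(O)O)cc3)c2n1`: 8830 nM
- compound 3 `O=C(NCCCOc1no[n+]([O-])c1S(=O)(=O)c1ccccc1)c1ccc2cccc(O)c2n1`: 9240 nM

Among the measured compounds shown here, compound 2, at 8830 nM, stands within the scatter of both other compounds in this assay, so the series so far shows no separation. The next compound to consider is compound 4 `CC1(C)OB(c2ccc(COc3cccc4ccc(C(=O)NCCCOc5no[n+]([O-])c5S(=O)(=O)c5ccccc5)nc34)cc2)OC1(C)C`, which differs from compound 2 as follows: a group of 9 heavy atoms (6 carbon, 1 boron, 2 oxygen; one five-membered non-aromatic ring with 3 hetero atoms) in place of a group of 3 heavy atoms (1 boron, 2 oxygen; no ring), on an aromatic carbon. For the measured compounds named here, no measured compound carries the entering group, so no measured step covers this exact change. The closest evidence is a 1.0-fold higher number from compound 2 to compound 3 (0.02 log units; within the scatter), which removes the entire group bearing the changed end and stays within the scatter. On that single step, no change beyond the scatter is expected in this assay. The expected result is a 1.1-fold lower number from compound 2 to compound 4 (0.04 log units; within the scatter), and this rests on thin evidence. For compound 4 the estimated value is 8000 nM, with an expected range of 4000 nM to 16000 nM.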

Compound 4, half-maximal inhibitory concentration: 15700 nM
Compound 4: the middle estimate sits 2.0-fold (0.29 log units) below what was measured; low and high end bracket the measured number.
By their numbers in this assay, from the lowest: compounds 1, 2, 3 and 4 (each within the scatter of the next, the first and the last beyond it).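

In this assay, the end of the side group can be exchanged on the aromatic carbon para to a large group, and the group of 9 heavy atoms with its five-membered non-aromatic ring in place of the group of 3 heavy atoms gives a 1.8-fold higher number from compound 2 to compound 4 (0.25 log units; within the scatter). The earlier step removed the whole group, whereas this one changes only its end, going from 2 hydrogen-bond donors to 0 and adding a ring, without leaving the scatter. Nothing available gives a reason for this result.

The compounds shown leave open whether a carboxylic acid or an amine on this aromatic carbon would give a step beyond the scatter in this assay. They also leave open how either group of the boron pair behaves on the core of compound 1.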